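A Methoxy Group Added to Compound 1

This account rests on a few compounds, and the source may have more. Where it says the series, first, only, none or still open, it means among the compounds named here.

Measured in a functional assay, read by spectrophotometry, with a stated time of 10 min (a lower number here means that less compound is needed, a higher number that more compound is needed for the effect), so far:
compound 1 `COC(=O)C1=C(C)NC(=O)NC1c1ccc(O)cc1` gives 0.79 ug/mL
compound 2 `COC(=O)C1=C(C)NC(=O)NC1c1ccc([N+](=O)[O-])cc1` gives 1.71 ug/mL
compound 3 `CCOC(=O)C1=C(C)NC(=O)NC1c1ccc(O)cc1` gives 0.89 ug/mL

Compound 1 sits at the low end of these numbers, level with compound 3. The extra methyl of compound 3 gives a 1.1-fold higher number from compound 1 to compound 3 (0.05 log units; within the scatter) and so no real change. Nitro in place of hydroxy gives a 2.2-fold higher number from compound 1 to compound 2 (0.34 log units; beyond the scatter) as a modest step. Compound 4 `COC(=O)C1=C(C)NC(=O)NC1c1ccc(O)c(OC)c1` is still unmeasured, and it differs from compound 1 thus: methoxy in place of hydrogen on an aromatic carbon with methoxy ortho to a hydroxy group and meta to a large group. Compound 4 keeps the hydroxy that compound 2 lost, so neither measured step matches this change closely. The expected result is a 1.1-fold higher number from compound 1 to compound 4 (0.03 log units; within the scatter) in this assay and thus no step beyond the scatter. The estimate for compound 4 is 0.85 ug/mL with an expected range from 0.4 ug/mL to 1.8 ug/mL until it is measured.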

Compound 4, half-maximal effective concentration: 0.9 ug/mL
Compound 4: middle estimate off by 1.1-fold (0.02 log units), on the low side, within the range that was stated.
By their numbers in this assay, from the lowest: compounds 1, 3, 4 and 2 (each within the scatter of the next, the first and the last beyond it).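

In this assay methoxy in place of hydrogen, ortho to a hydroxy group and meta to a large group, gives a 1.1-fold higher number from compound 1 to compound 4 (0.06 log units; within the scatter) and so no step beyond the scatter. Among the compounds shown here, the earlier compounds replaced the hydroxy group or added a methyl elsewhere, so this is the first sign that this aromatic carbon can carry a group without a real shift in the number. Nothing at hand explains this result. Still open, from the compounds shown here alone, is how an amine, a chlorine atom or a longer chain such as ethoxy would behave on this same carbon.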